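The compounds below may be only part of what the source reports. "The series", "measured", "known", "first", "only" and "open" are said of these compounds alone.

Values in a functional assay on MDA-MB-231 cells (Homo sapiens) for antiproliferative activity, read by MTT assay, with a stated time of 72 h (a lower number here means a stronger inhibitor, a higher number a weaker inhibitor), each one a limit of the assay and not a number:

Compound 1 `CCCn1ccnc1-c1cc(OC)c(OC)c(OC)c1`: > 100000 nM
Compound 2 `COc1cc(-c2nccn2C(C)C)cc(OC)c1OC`: > 100000 nM
Compound 3 `COc1cc(-c2nccn2Cc2ccccc2)cc(OC)c1OC`: > 100000 nM

Compound 3 stands with the other two, since all three share (the limit of > 100000 nM in this assay, at which 3 of the 3 values shown sit). No true potency can be read for any of them. The next compound, compound 4 `COc1cc(-c2nccn2-c2cccc(C)c2)cc(OC)c1OC`, keeps the shared core and has 3-methylphenyl in place of benzyl on an aromatic nitrogen.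

The measured comparisons that bear on this change concern the same nitrogen: a step that the two limits leave unreadable from compound 1 to compound 2, a step that the two limits leave unreadable from compound 1 to compound 3 and a step that the two limits leave unreadable from compound 2 to compound 3. None of them has a readable size, and none involves 3-methylphenyl. Among the measured compounds shown here, they show only that three different groups there all stayed at the limit. Starting from a limit, any readable change could only point towards a stronger inhibitor, and another limit remains quite possible.

The expected change is an at least 3.3-fold lower number from compound 3 to compound 4 (0.52 log units; beyond the scatter), a rough guess with no measured size behind it. For compound 4 the estimate is 30000 nM, with an expected range of 2000 nM to 100000 nM.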

Compound 4, half-maximal inhibitory concentration: 11700 nM
Compound 4: middle estimate off by 2.6-fold (0.41 log units), on the high side, within the range that was stated.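

In this assay, 3-methylphenyl on this aromatic nitrogen is the first group shown to give a readable value, with an at least 8.5-fold lower number from compound 3 to compound 4 (0.93 log units; beyond the scatter), and it also stands clear of the other two groups, with an at least 8.5-fold lower number from compound 2 to compound 4 (0.93 log units; beyond the scatter) and an at least 8.5-fold lower number from compound 1 to compound 4 (0.93 log units; beyond the scatter). Benzyl and 3-methylphenyl have the same atoms, joined differently, so this position responds to how those atoms are arranged and not merely to their number. Each step is only a minimum, because the earlier compounds sit at a limit of the assay: the limit of > 100000 nM in this assay, at which 3 of the 4 values shown sit.

Whether the ring bound directly to the nitrogen or its methyl group accounts for the difference stays open, and plain phenyl or 4-methylphenyl would bear on that. Also open, from the compounds shown here alone, is what a phenyl ring carrying an amine or a carboxylic acid would do here.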